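The compounds below may be only part of what the source reports. "The series", "measured", "known", "first", "only" and "open" are said of these compounds alone.

Within the data shown here, compound 1 `CC1=CC[C@H]2[C@@H]1CC=C(C)[C@@H](CCC1=C(C)CC[C@@H]3OC(C)(C)[C@@H](O)CC[C@@]13C)C2(C)C`, compound 2 `CC1=CC[C@H]2[C@H](CC[C@]2(C)O)C(C)(C)[C@@H]1CC[C@H]1[C@]2(C)CC[C@H](OC(=O)c3ccccc3)C(C)(C)O[C@H]2CC[C@@]1(C)O` and compound 3 `CC1=CC[C@H]2[C@@H]1CC=C(C)[C@@H](CC[C@H]1[C@]3(C)CC[C@H](OC(=O)c4ccncc4)C(C)(C)O[C@H]3CC[C@@]1(C)O)C2(C)C` share one core, and among them compound 2 is the only one that returns a number. In a functional assay on MCF7 cells (Homo sapiens) for antiproliferative activity, read by MTT assay, with a stated time of 72 h (a higher number here means a weaker inhibitor, a lower number a stronger inhibitor), compound 2 gives 21000 nM. Compound 1 reaches only the limit of the assay, > 50000 nM. Compound 3 likewise gives only a limit, > 50000 nM. The set is thus framed by the limit of > 50000 nM in this assay, at which 2 of the 3 values shown sit. Compound 4 `CC1=CC[C@H]2[C@H](CC[C@]2(C)O)C(C)(C)[C@@H]1CC[C@H]1[C@]2(C)CC[C@H](OC(=O)c3ccccc3[N+](=O)[O-])C(C)(C)O[C@H]2CC[C@@]1(C)O` differs from compound 2 in one place: nitro in place of hydrogen on an aromatic carbon. Among the measured compounds shown here, no step between two measured numbers is available, so the size of the move in this assay from compound 2 to compound 4 cannot be read from the data, and no change beyond the scatter is expected. Compound 4 is therefore estimated at 25000 nM, within 8000 nM to 60000 nM, an expected step of a 1.2-fold higher number from compound 2 to compound 4 (0.08 log units; within the scatter).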

Compound 4, half-maximal inhibitory concentration: 5200 nM
Beside the measured number, compound 4's estimate is 4.8-fold (0.68 log units) above it; measured number outside the range, below it.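

Among these compounds, the change gives a 4.0-fold lower number from compound 2 to compound 4 (0.61 log units; beyond the scatter) in this assay and is the first step in this set that can be read. It shows that the phenyl ring of the benzoyloxy group in compound 2 does not tolerate every change silently: nitro on an aromatic carbon, ortho to a large group, moves the number beyond the scatter. Nothing measured here accounts for that move. The compounds shown leave open whether an amine or a carboxylic acid in that same place would move the number in the same direction or as far.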